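The source may report more compounds than this note shows. Statements on the series, on what has been measured and on what is new or still open speak of the compounds shown alone.

Measured in an ADME assay on L6 cells (Rattus norvegicus) for cytotoxicity, read by resazurin assay, with a stated time of 70 h; on this read-out higher numbers stand for weaker inhibition and lower numbers for stronger inhibition:
Compound 1 `c1ccc(OCCCOc2ccc(-c3cc4ccc(C5=NCCN5)cc4o3)cc2)cc1` gives 16800 nM.
Compound 2 `N=C(N)c1ccc2cc(-c3ccc(OCCCCCCOc4ccccc4)cc3)oc2c1` gives 8000 nM.
Compound 3 `CC(C)NC(=N)c1ccc2cc(-c3ccc(OCCCCCCOc4ccccc4)cc3)oc2c1` gives 4900 nM.

Compound 3 gives the lowest of the three numbers in this assay. Its nearest neighbour is compound 2, and the step of a 1.6-fold lower number from compound 2 to compound 3 (0.21 log units; within the scatter) lies within the scatter. The furthest is compound 1, whose value stands clearly beyond the scatter from compound 3; as compound 1 and compound 3 differ in more than one place, their two values alone are what is known.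

Compound 4 `c1ccc(OCCCCCCOc2ccc(-c3cc4ccc(C5=NCCN5)cc4o3)cc2)cc1` differs from compound 3 by a group of 5 heavy atoms (3 carbon, 2 nitrogen; one five-membered non-aromatic ring with 2 hetero atoms) in place of a group of 6 heavy atoms (4 carbon, 2 nitrogen; no ring), on an aromatic carbon. The position is on an aromatic carbon of a six-membered aromatic ring of carbon only, part of a fused or bridged system of two rings; meta to a fused ring; para to a fused ring.

For the measured compounds named here, only one measured step touches this part of the shared core, the step from compound 2 to compound 3, which changed the same group and stayed within the scatter. Going by the values given here, no measured step exchanges this group for the ring-containing one on an otherwise identical chain. The step is therefore expected to be small, with no clear direction, and compound 4 is expected to give about 8000 nM, in the range 3000 nM to 20000 nM, which would mean a 1.6-fold higher number from compound 3 to compound 4 (0.21 log units; within the scatter).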

Compound 4, half-maximal inhibitory concentration: 3400 nM
Estimate against measurement, compound 4: 2.4-fold (0.37 log units) above; low and high end bracket the measured number.
By their numbers in this assay, from the lowest: compounds 4, 3 and 2 (each within the scatter of the next, the first and the last beyond it); then compound 1.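

In this assay, the step of a 1.4-fold lower number from compound 3 to compound 4 (0.16 log units; within the scatter) replaces the open group with the one holding a five-membered non-aromatic ring, and this exchange on the aromatic carbon does not separate the two groups. Against the smaller open group with no ring, however, the same ring gives a 2.4-fold lower number from compound 2 to compound 4 (0.37 log units; beyond the scatter), which is beyond the scatter, whereas the earlier step at this position, adding isopropyl on an amine nitrogen, was not. For the compounds shown here, with the ring group held fixed, the chain also registers for the first time, since 3-phenoxypropyl in place of phenoxy gives a 4.9-fold lower number from compound 1 to compound 4 (0.69 log units; beyond the scatter), so the number responds to the chain as well as to the group on the aromatic carbon.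

No measurement shown here accounts for any of these steps. Going by these compounds alone, it remains open how a six-membered ring carrying two nitrogens, or an isopropyl on a nitrogen of the five-membered ring, would read at this position, and how a chain longer than the one in compound 4 would read with the ring group kept in place.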